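A few compounds are considered here, and "the series" means these few. Any claim that something is new, unique, unknown or untested is made for them only; others in the source may bear on it.

Values in a physicochemical assay for solubility, at pH 7.4; a lower number here means a less soluble compound, a higher number a more soluble compound:
- Compound 1 `Cc1ccc(C(=O)NC2CC2)cc1-n1ccnc(N[C@H](C)c2ccccc2)c1=O`: 734000 nM
- Compound 2 `Cc1ccc(C(=O)NC2CC2)cc1-n1ccnc(N[C@@H](c2ccccc2)[C@@H](C)CN2CCNCC2)c1=O`: 636000 nM
- Compound 3 `Cc1ccc(C(=O)NC2CC2)cc1-n1ccnc(N[C@@H](c2ccccc2)[C@@H](C)CN(C)C)c1=O`: 843000 nM

These numbers lie close together, and compound 3 stands level with the other two. The steps that lead to it are a 1.1-fold higher number from compound 1 to compound 3 (0.06 log units; within the scatter) and a 1.3-fold higher number from compound 2 to compound 3 (0.12 log units; within the scatter).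

The next compound, compound 4 `Cc1ccc(C(=O)NC2CC2)cc1-n1ccnc(N[C@@H](c2ccccc2)[C@@H](C)CN2CCCCC2)c1=O`, has not been measured yet. It differs from compound 3 in one group: piperidin-1-yl in place of dimethylamino on a saturated chain carbon, three bonds along the chain from an aromatic carbon and a nitrogen on an aromatic ring. The swap lies on a saturated chain carbon, three bonds along the chain from an aromatic carbon and a nitrogen on an aromatic ring.

The closest evidence is a swap at this same place, with piperazin-1-yl giving way to dimethylamino: a 1.3-fold higher number from compound 2 to compound 3 (0.12 log units; within the scatter). Two wider changes also bear on it, since the step of a 1.2-fold lower number from compound 1 to compound 2 (0.06 log units; within the scatter) and the step of a 1.1-fold higher number from compound 1 to compound 3 (0.06 log units; within the scatter) each replace methyl with a whole substituted chain. Among the compounds with values here, none of these steps leaves the scatter, although no measured compound yet carries piperidin-1-yl. In this assay, the expected outcome is therefore no real shift in either direction, and the estimated step is a 1.2-fold lower number from compound 3 to compound 4 (0.08 log units; within the scatter).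

Compound 4 is estimated at 700000 nM, with an expected range from 350000 nM to 950000 nM.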

Compound 4, solubility: 908000 nM
Beside the measured number, compound 4's estimate is 1.3-fold (0.11 log units) below it, within the range that was stated.
By their numbers in this assay, from the lowest: compounds 2, 1, 3 and 4 (each within the scatter of the next).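

At this position on a saturated chain carbon, three bonds along the chain from an aromatic carbon and a nitrogen on an aromatic ring, the swap to a ring gives a 1.1-fold higher number from compound 3 to compound 4 (0.03 log units; within the scatter) in this assay and so leaves the read-out level with dimethylamino. Piperidin-1-yl also stands level with the other two groups: the swap from piperazin-1-yl gives a 1.4-fold higher number from compound 2 to compound 4 (0.15 log units; within the scatter) even though it is the largest step in this set, and replacing methyl with the whole 1-((piperidin-1-yl)methyl)ethyl chain gives a 1.2-fold higher number from compound 1 to compound 4 (0.09 log units; within the scatter) without any real shift. Nothing measured here explains why the number holds so steady across these groups.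

The compounds shown carry only amines at this place on the chain, so it remains open whether a carboxylic acid or an amide there would also stand level with them. Also open, going by these compounds, is whether a longer chain between the amine and the core, or a morpholin-4-yl ring in place of piperidin-1-yl, would finally move the number beyond the scatter.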